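A few compounds are considered here, and "the series" means these few. Any claim that something is new, unique, unknown or untested is made for them only; others in the source may bear on it.

Measured compounds:
Compound 1 `CC(C(=O)NCc1ccc(C(F)(F)F)cc1N1CCCCCCC1)c1ccc(NS(C)(=O)=O)c(F)c1` gives 2.8 nM in an assay on CHO cells for antagonist activity at transient receptor potential cation channel subfamily V member 1 (Homo sapiens), read by FLIPR; a lower number here means a stronger inhibitor, a higher number a weaker inhibitor.
Compound 2 `CC(C(=O)NCc1ccc(C(F)(F)F)cc1N1CCC(C)(C)CC1)c1ccc(NS(C)(=O)=O)c(F)c1` gives 1.3 nM in this assay.
Compound 3 `CCCOc1cc(C(F)(F)F)ccc1CNC(=O)C(C)c1ccc(NS(C)(=O)=O)c(F)c1` gives 2 nM in this assay.

Compound 3 sits second highest of the three numbers, within the scatter of both neighbours: one step is a 1.4-fold lower number from compound 1 to compound 3 (0.15 log units; within the scatter), and the other step is a 1.5-fold higher number from compound 2 to compound 3 (0.19 log units; within the scatter).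

Compound 4 `CC(C(=O)NCc1ccc(C(F)(F)F)cc1OC1CCCCC1)c1ccc(NS(C)(=O)=O)c(F)c1` differs from compound 3 by cyclohexyl in place of propyl on an oxygen on an aromatic ring. For the measured compounds named here, no measured step exchanges propyl for cyclohexyl on that oxygen. What bears on it is the variation of the group on the same aromatic carbon: a 2.2-fold lower number from compound 1 to compound 2 (0.33 log units; beyond the scatter) is the largest step seen, while a 1.4-fold lower number from compound 1 to compound 3 (0.15 log units; within the scatter) and a 1.5-fold higher number from compound 2 to compound 3 (0.19 log units; within the scatter) stay within the scatter. Across a six-membered ring, an eight-membered ring and a propoxy chain at that place the numbers move little, so for compound 4 in this assay a step of about no change at the digits printed from compound 3 to compound 4 (within the scatter) is expected, not beyond the scatter in either direction. Compound 4 is estimated at 2 nM, with a range from 0.8 nM to 5 nM.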

Compound 4, inhibition constant: 0.7 nM
Compound 4: middle estimate off by 2.9-fold (0.46 log units), on the high side; the measured number lies below the stated range.
By their numbers in this assay, from the lowest: compounds 4, 2, 3 and 1 (each within the scatter of the next, the first and the last beyond it).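

In this assay, for the compounds shown here, cyclohexyl in place of propyl on the oxygen gives a 2.9-fold lower number from compound 3 to compound 4 (0.46 log units; beyond the scatter) and is the only step here that changes the group on that oxygen alone, so this place responds to the change by more than the scatter. Measured against the groups held through nitrogen, the picture is split: a 4.0-fold lower number from compound 1 to compound 4 (0.60 log units; beyond the scatter) lies beyond the scatter, whereas a 1.9-fold lower number from compound 2 to compound 4 (0.27 log units; within the scatter) stays within it, so cyclohexyloxy and 4,4-dimethylpiperidin-1-yl cannot be ordered. Nothing available accounts for the gain seen with cyclohexyl.

Open, as far as these compounds go, is whether the step follows from the ring itself or simply from more carbon on the oxygen, which cyclopentyl, cycloheptyl or an open chain such as hexyl would separate. Also open, from the compounds shown here alone, is how a tetrahydropyranyl ring or a phenyl ring on that oxygen would read.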